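Lengthening the amide substituent: methylamino to ethylamino

A few compounds are considered here, and "the series" means these few. Any claim that something is new, unique, unknown or untested is made for them only; others in the source may bear on it.

The measured compounds:
Compound 1, `COC(=O)C(C)(C)C(c1ccc(Nc2ccccc2)cc1)n1cncn1`: in an assay on microsomes from MCF7 cells for inhibition of cytochrome P450 26A1 (Homo sapiens), read by scintillation counting, with a stated time of 1 h (on this read-out lower numbers stand for stronger inhibition and higher numbers for weaker inhibition), compound 1 gives 13 nM.
Compound 2, `CC(C)(C(=O)O)C(c1ccc(Nc2ccccc2)cc1)n1ccnc1`: in this assay compound 2 gives > 1000 nM, which is a limit of the assay and not a number.
Compound 3, `CNC(=O)C(C)(C)C(c1ccc(Nc2ccccc2)cc1)n1ccnc1`: in this assay compound 3 gives 200 nM.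

Among the compounds with values here, of the two numbers known, compound 3 carries the higher one; compound 1 gives the lower. Within the data shown here, the one measured step that touches the amide end of the molecule is an at least 5.0-fold lower number from compound 2 to compound 3 (0.69 log units; beyond the scatter), where methylamino replaced hydroxy on the carbonyl carbon.

Compound 4 is `CCNC(=O)C(C)(C)C(c1ccc(Nc2ccccc2)cc1)n1ccnc1`. Relative to compound 3 it shows (methyl in place of hydrogen on a saturated chain carbon bound to an amide-type nitrogen). Among the measured compounds shown here, this is a far smaller alteration than the one from compound 2 to compound 3, and no measured pair shows what lengthening the group on the amide nitrogen does. The expectation is therefore no step beyond the usual scatter: compound 4 is expected to give 170 nM in this assay, between 60 nM and 500 nM, which means an expected step of a 1.2-fold lower number from compound 3 to compound 4 (0.07 log units; within the scatter).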

Compound 4, half-maximal inhibitory concentration: 250 nM
Compound 4: the middle estimate sits 1.5-fold (0.17 log units) below what was measured, within the range that was stated.
By their numbers in this assay, from the lowest: compound 1; then compounds 3 and 4 (each within the scatter of the next). At a limit, above all of these: compound 2.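

Adding one methyl to the group on the amide nitrogen gives a 1.3-fold higher number from compound 3 to compound 4 (0.10 log units; within the scatter), so this assay does not separate methylamino from ethylamino at this position. Ethylamino in place of hydroxy on the carbonyl carbon gives an at least 4.0-fold lower number from compound 2 to compound 4 (0.60 log units; beyond the scatter), which shows that the step seen earlier with methylamino is not confined to that one amide. The value of compound 2 is a limit of the assay and not a number, so the true size of this step stays unknown: the limit of > 1000 nM in this assay, at which 1 of the 4 values shown sits.

The compounds shown leave open what a longer chain such as propyl or butyl on the amide nitrogen would give, and whether a second methyl on that nitrogen would matter. Compound 1 differs from compound 3 and compound 4 in more than one place, so it cannot show which change separates it from these amides.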